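Cytotoxicity of Ester Analogues: Shortening the Acyl Chain

The compounds below may be only part of what the source reports. "The series", "measured", "known", "first", "only" and "open" are said of these compounds alone.

Compound 1 `Cc1cn([C@H]2CO[C@@H](COC(=O)C(C)(C)C)O2)c(=O)[nH]c1=O` — 18100 nM
Compound 2 `Cc1cn([C@H]2CO[C@@H](COC(=O)C3CCCCC3)O2)c(=O)[nH]c1=O` — > 100000 nM
Compound 3 `CCCCCCCCCCCC(=O)OC[C@@H]1OC[C@H](n2cc(C)c(=O)[nH]c2=O)O1` — > 100000 nM

Three esters of a shared core have been measured. In an ADME assay on Vero cells (Chlorocebus sabaeus) for cytotoxicity, read by MTT assay, with a stated time of 3 days (a lower number here means a stronger inhibitor, a higher number a weaker inhibitor), compound 1 gives 18100 nM. Compound 2 reaches only a limit of the assay, > 100000 nM. Compound 3 also stands at a limit of the assay, > 100000 nM, so for compound 3 no number is known, only that it lies beyond the range measured. Going by the values given here, the one measured step, an at least 5.5-fold higher number from compound 1 to compound 2 (0.74 log units; beyond the scatter), concerns a different part of the molecule.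

Compound 4 `CCCCCCCC(=O)OC[C@@H]1OC[C@H](n2cc(C)c(=O)[nH]c2=O)O1` differs from compound 3 by hydrogen in place of butyl on a saturated chain carbon, seven bonds along the chain from a carbonyl carbon. Among the compounds with values here, no measured step touches this chain, so the measured step gives no direct guide. What can be said is that the limit of > 100000 nM in this assay, at which 2 of the 3 values shown sit, shows weak inhibition for most of the series, and compound 3 itself sits there. Compound 4 is therefore expected to remain near the limit, with a number no higher from compound 3 to compound 4 (the limit leaves the size open) as the expected step. The estimate for compound 4 is 100000 nM, between 35000 nM and 300000 nM.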

Compound 4, half-maximal inhibitory concentration: > 100000 nM
Compound 4: no number, only a limit (the forecaster's own chance of this, stated with the estimate: 65%); the middle value sits exactly at the limit.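

In this assay, hydrogen in place of butyl on this saturated chain carbon leaves the ester at a limit of the assay, so this cut along the chain does not yield a readable number. Heptyl in place of tert-butyl on a carbonyl carbon gives an at least 5.5-fold higher number from compound 1 to compound 4 (0.74 log units; beyond the scatter), which shows that a straight chain of this length, like the cyclohexyl group before it, stays clear of the number held by compound 1: the limit of > 100000 nM in this assay, at which 3 of the 4 values shown sit. The steps that link compound 4 to compound 3 and to compound 2 cannot be read, as limits stand at both ends.

From the compounds shown here alone, whether a shorter chain such as propyl, or a small ring such as cyclopropyl, on the carbonyl carbon would give a number short of the limit stays open. So does how far beyond the limit compound 2, compound 3 and compound 4 lie, and whether they differ at all.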